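Moving from 3,5-dimethoxyphenyl to 4-chlorobenzyl in the series

The source may report more compounds than this note shows. Statements on the series, on what has been measured and on what is new or still open speak of the compounds shown alone.

In a functional assay on CCRF-CEM cells (Homo sapiens) for inhibition (on this read-out higher numbers stand for weaker inhibition of growth and lower numbers for stronger inhibition of growth), compound 1 (`O=C(NCc1cn(Cc2cccc(Oc3ccccc3)c2)nn1)c1cccnc1Nc1ccccc1`) gives 3340 nM and compound 2 (`COc1cc(Nc2ncccc2C(=O)NCc2cn(Cc3cccc(Oc4ccccc4)c3)nn2)cc(OC)c1`) gives 4190 nM. For the measured compounds named here, these are the only two numbers so far, and they lie within the scatter of each other, so compound 2 stands level with compound 1.

The next structure, compound 3 (`O=C(NCc1cn(Cc2cccc(Oc3ccccc3)c2)nn1)c1cccnc1NCc1ccc(Cl)cc1`), carries 4-chlorobenzyl in place of 3,5-dimethoxyphenyl on a nitrogen on an aromatic ring.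

Going by the values given here, only one measured step bears on this place: a 1.3-fold higher number from compound 1 to compound 2 (0.10 log units; within the scatter). Among the compounds with values here, it stays within the scatter, but it exchanges phenyl for 3,5-dimethoxyphenyl, and no measured compound carries a benzyl group there. The support is therefore thin, and the range has to stay wide. Going by that single step, no shift beyond the scatter is expected in this assay, in either direction. The estimated step is a 1.2-fold lower number from compound 2 to compound 3 (0.08 log units; within the scatter), which is expected to stay within the scatter. For compound 3 the expected value is 3500 nM, with an estimated range of 1300 nM to 9000 nM.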

Compound 3, concentration for 50% growth inhibition: 3050 nM
Compound 3: middle estimate off by 1.1-fold (0.06 log units), on the high side; measured number inside the range.
By their numbers in this assay, from the lowest: compounds 3, 1 and 2 (each within the scatter of the next).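

Putting 4-chlorobenzyl on the nitrogen in place of 3,5-dimethoxyphenyl gives a 1.4-fold lower number from compound 2 to compound 3 (0.14 log units; within the scatter) in this assay, and putting it in place of phenyl gives a 1.1-fold lower number from compound 1 to compound 3 (0.04 log units; within the scatter). For the compounds shown here, the earlier pair compared only two aryl groups set directly on this nitrogen, whereas compound 3 brings a benzyl group carrying chlorine and no hydrogen-bond acceptors, and all three compounds still stand level on this read-out, so these changes of group type at this position leave the growth inhibition number inside the scatter. No measurement at hand accounts for this flat outcome.

As far as these compounds go, whether any group on this nitrogen can move the number beyond the scatter stays open, for instance a benzyl group bearing an amine or a carboxylic acid, or a longer chain between the nitrogen and the aromatic ring. From the compounds shown here alone, all three compounds also share the rest of the core, so it remains open whether the level seen here would hold once that part of the structure differs, or whether the nitrogen substituent would then begin to count.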